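The source may report more compounds than this note shows. Statements on the series, on what has been measured and on what is new or still open speak of the compounds shown alone.

Measured values:
- Compound 1 `CCc1nc2nc(C)cc(Nc3cccc(Cl)c3)n2n1`: 78.3 mL.min-1.g-1
- Compound 2 `Cc1cc(Nc2ccc(S(F)(F)(F)(F)F)cc2)n2nc(C(F)(F)F)nc2n1`: < 5 mL.min-1.g-1 (a limit of the assay, not a number)
- Compound 3 `Cc1cc(Nc2ccc(S(F)(F)(F)(F)F)cc2)n2nc(C3CC3)nc2n1`: < 5 mL.min-1.g-1 (a limit of the assay, not a number)

For the measured compounds named here, in an in vitro ADME assay on microsomes from liver (Homo sapiens) for metabolic stability (a lower number here means slower removal, a higher number faster removal of the compound), compound 1 gives 78.3 mL.min-1.g-1, the only true number in this small set. Compound 2 and compound 3 both rest at the limit of < 5 mL.min-1.g-1 in this assay, at which 2 of the 3 values shown sit.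

The next compound, compound 4 `Cc1cc(Nc2cccc(Cl)c2)n2nc(C(C)(F)F)nc2n1`, is still unmeasured. It differs from compound 1 as follows: 1,1-difluoroethyl in place of ethyl on an aromatic carbon. In short, 1,1-difluoroethyl stands in place of ethyl on an aromatic carbon.

Going by the values given here, the one measured step, a step that the two limits leave unreadable from compound 2 to compound 3, is cyclopropyl in place of trifluoromethyl on an aromatic carbon. It offers no size to carry over, and compounds 2 and 3 also differ from compound 1 elsewhere in the structure. The expectation of a fall is therefore only a loose one, resting on compound 1 at 78.3 mL.min-1.g-1 having plenty of room to drop in this assay. A moderate fall is expected, an estimated 3.1-fold lower number from compound 1 to compound 4 (0.50 log units; beyond the scatter). For compound 4 the estimated value is 25 mL.min-1.g-1, with an expected range from 8 mL.min-1.g-1 to 65 mL.min-1.g-1.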

Compound 4, intrinsic clearance in microsomes: 44.4 mL.min-1.g-1
Compound 4: middle estimate off by 1.8-fold (0.25 log units), on the low side; measured number inside the range.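

In this assay compound 2 and compound 3 could put no size on a change at this aromatic carbon, because each gives only a limit of the assay and not a number: the limit of < 5 mL.min-1.g-1 in this assay, at which 2 of the 4 values shown sit. Placing 1,1-difluoroethyl where ethyl stood now gives the first readable step at this position, a 1.8-fold lower number from compound 1 to compound 4 (0.25 log units; within the scatter), so the two compounds cannot be told apart in this read-out. At this place, on the five-membered ring between two ring nitrogen atoms, the two entering fluorine atoms therefore do not separate compound 4 from compound 1.

On these data alone, whether another group here, such as an amine, a carboxylic acid or a longer chain, would give a step beyond the scatter remains open. Also open, as far as these compounds go, is whether this same swap would read alike with other groups elsewhere on the shared core.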